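This account rests on a few compounds, and the source may have more. Where it says the series, first, only, none or still open, it means among the compounds named here.

Compound 1 `Cc1ccc(NC(=O)c2cc(Oc3ccc(S(C)(=O)=O)cc3)cc(OC(C)C)c2)nc1` gives 4.05 in a physicochemical assay for lipophilicity, using the shake flask method; a lower number here means a more polar compound, a higher number a more lipophilic compound.
Compound 2 `Cc1cnc(-c2cc(Oc3ccc(S(C)(=O)=O)cc3)cc(OC(C)C)c2)[nH]c1=O` gives 2.68 in this assay.

In this assay compound 2 stands lowest of the two measured compounds, set apart from compound 1 by the step of a number 1.37 log units lower from compound 1 to compound 2 (beyond the scatter). Compound 3 `CC(C)Oc1cc(Oc2ccc(S(C)(=O)=O)cc2)cc(-c2ncc(Cl)c(=O)[nH]2)c1` has not yet been measured. It differs from compound 2 by chloro in place of methyl on an aromatic carbon. Going by the values given here, the one measured step exchanged a whole ring, not a single substituent, so no measured step bears on this change. The expected shift is small, a number 0.22 log units higher from compound 2 to compound 3 (within the scatter), inside the scatter. The estimate for compound 3 in this assay is 2.9, between 2.5 and 3.3.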

Compound 3, distribution coefficient: 2.04
Compound 3: the middle estimate sits 0.86 log units above what was measured, outside the stated range (below it).
By their numbers in this assay, from the lowest: compound 3; then compound 2; then compound 1.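

Swapping methyl for chloro on this aromatic carbon, two atoms from the ring nitrogen, exchanges one heavy atom for another, yet in this assay it gives a number 0.64 log units lower from compound 2 to compound 3 (beyond the scatter). The full span of the series is now a number 2.01 log units lower from compound 1 to compound 3 (beyond the scatter). Nothing available explains the direction of this shift.

Going by these compounds, it remains open whether fluoro, bromo or a nitrile on this carbon would move the number the same way. On these data alone, it is also open whether chloro in place of methyl would give a similar step on a different core.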